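A Benzyl Swap Under a Solubility Limit

The source may report more compounds than this note shows. Statements on the series, on what has been measured and on what is new or still open speak of the compounds shown alone.

In a physicochemical assay for solubility (on this read-out lower numbers stand for lower solubility and higher numbers for higher solubility), compound 2 (`O=C(O)c1ccc(C(=O)/C(=C\c2ccc(F)c([N+](=O)[O-])c2)SCc2ccc(C(F)(F)F)cc2)cc1`) gives < 1000 ug/mL as a limit and not as a number. Compound 1 (`O=C(O)c1ccc(C(=O)/C(=C\c2ccc(F)c([N+](=O)[O-])c2)Sc2ccc(Br)cc2)cc1`) likewise gives < 1000 ug/mL as a limit. Compound 3 (`O=C(O)c1ccc(C(=O)/C(=C\c2ccc(Br)c([N+](=O)[O-])c2)SCc2ccc(Br)cc2)cc1`) also gives < 1000 ug/mL as a limit. The evidence so far therefore amounts to the limit of < 1000 ug/mL in this assay, at which 3 of the 3 values shown sit, and nothing finer.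

Compound 4 (`O=C(O)c1ccc(C(=O)/C(=C\c2ccc(F)c([N+](=O)[O-])c2)SCc2ccccc2Cl)cc1`) departs from compound 2 in one place (2-chlorophenyl in place of 4-(trifluoromethyl)phenyl on a saturated chain carbon bound to a sulfur). It carries 2-chlorophenyl in place of 4-(trifluoromethyl)phenyl on a saturated chain carbon bound to a sulfur, so that 4-(trifluoromethyl)benzyl becomes 2-chlorobenzyl.

Among the measured compounds shown here, the one measured step that bears on this change (a step that the two limits leave unreadable from compound 1 to compound 2) also alters the group on sulfur, but it offers neither a size nor a direction. The expected step (a step that the limit leaves unreadable from compound 2 to compound 4) is therefore none beyond the scatter. Compound 4 is estimated at 600 ug/mL in a range from 200 ug/mL to 1000 ug/mL and is expected most likely to be reported only as a limit again.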

Compound 4, solubility: < 1000 ug/mL
Compound 4 ended at the assay's limit; the forecaster's own chance of this, stated with the estimate: 90%; the middle value does not contradict the limit.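

In this assay compound 4 gives < 1000 ug/mL, again a limit and not a number. Among the compounds shown here, no step from compound 1 or compound 2 to compound 4 can be read. The compounds shown leave open where the actual solubility of each lies and whether the group on sulfur changes it.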